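Methoxy on the pendant phenyl of the shared core

The compounds below may be only part of what the source reports. "The series", "measured", "known", "first", "only" and "open" are said of these compounds alone.

Going by the values given here, compound 2 `Cn1cc(-c2ccccc2)c2cc(C(=O)NCc3ccc(C(=O)Nc4ccccc4N)cc3)[nH]c2c1=O` gives 230 nM in a functional assay on MV4-11 cells (Homo sapiens) for antiproliferative activity, read by CCK-8 assay, with a stated time of 72 h (on this read-out lower numbers stand for stronger inhibition and higher numbers for weaker inhibition), the higher of the two numbers known; compound 1 `Cn1cc(-c2ccccc2Oc2ccccc2)c2cc(C(=O)NCc3ccc(C(=O)Nc4ccccc4N)cc3)[nH]c2c1=O` gives 80 nM, and the step of a 2.9-fold higher number from compound 1 to compound 2 (0.46 log units; beyond the scatter) shows that stripping the phenoxy from the phenyl raised the number. Compound 3 `COc1ccc(-c2cn(C)c(=O)c3[nH]c(C(=O)NCc4ccc(C(=O)Nc5ccccc5N)cc4)cc23)cc1` carries methoxy in place of hydrogen on an aromatic carbon. Among the compounds with values here, the only measured step bearing on this is that of phenoxy removal, and it concerns a different group at a different place on the same ring, so it gives only a weak hint that substitution on this phenyl lowers the number. A small decrease is therefore expected, a 1.5-fold lower number from compound 2 to compound 3 (0.19 log units; within the scatter), possibly within scatter. Compound 3 is estimated at 150 nM, range 60 nM to 400 nM.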

Compound 3, half-maximal inhibitory concentration: 320 nM
Beside the measured number, compound 3's estimate is 2.1-fold (0.33 log units) below it; measured number inside the range.
By their numbers in this assay, from the lowest: compound 1; then compounds 2 and 3 (each within the scatter of the next).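

In this assay, the change from phenyl to 4-methoxyphenyl gives a 1.4-fold higher number from compound 2 to compound 3 (0.14 log units; within the scatter), so a methoxy para to a large group has no readable effect on the number. The phenoxy step, a 2.9-fold higher number from compound 1 to compound 2 (0.46 log units; beyond the scatter), concerns a different place on the same ring and does not carry over to this position. No measurement on hand accounts for the result.

Open, as far as these compounds go, is whether an amine or a carboxylic acid at this position would separate from compound 2. Also open, from the compounds shown here alone, is whether a phenoxy here would give a readable step.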